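Series notes: 4-chlorophenyl in place of thiophen-2-yl

The source may report more compounds than this note shows. Statements on the series, on what has been measured and on what is new or still open speak of the compounds shown alone.

Measured in a functional assay on CCRF-CEM cells (Homo sapiens) for inhibition, read by cell counting, with a stated time of 3 days; on this read-out higher numbers stand for weaker inhibition and lower numbers for stronger inhibition:
compound 1 `C=C(Br)C(=O)Nc1cccc(-c2cn3nc(Cc4cccc(OC)c4)sc3n2)c1` gives 3100 nM
compound 2 `C=C(Br)C(=O)Nc1cccc(-c2cn3nc(Cc4ccccc4)sc3n2)c1` gives 4200 nM
compound 3 `C=C(Br)C(=O)Nc1cccc(-c2cn3nc(-c4cccs4)sc3n2)c1` gives 410 nM

Compound 3 holds the lowest number of the three in this assay. The steps of a 7.6-fold lower number from compound 1 to compound 3 (0.88 log units; beyond the scatter) and a 10-fold lower number from compound 2 to compound 3 (1.01 log units; beyond the scatter) both lie beyond the scatter, so compound 3 is the strongest inhibitor measured so far. The step of a 1.4-fold higher number from compound 1 to compound 2 (0.13 log units; within the scatter) is within the scatter.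

Compound 4 `C=C(Br)C(=O)Nc1cccc(-c2cn3nc(-c4ccc(Cl)cc4)sc3n2)c1` differs from compound 3 in one place: 4-chlorophenyl in place of thiophen-2-yl on an aromatic carbon. Going by the values given here, no measured step exchanges one directly attached aromatic ring for another. The two steps that bear on it, a 7.6-fold lower number from compound 1 to compound 3 (0.88 log units; beyond the scatter) and a 10-fold lower number from compound 2 to compound 3 (1.01 log units; beyond the scatter), each put thiophen-2-yl in place of a benzyl or 3-methoxybenzyl group, and compound 4 keeps a directly attached aromatic ring rather than a benzyl group. The expectation is therefore a step of a 1.5-fold higher number from compound 3 to compound 4 (0.17 log units; within the scatter) that stays within or only a little beyond the scatter, with no firm direction. Compound 4 is expected to give 600 nM in this assay, in the range 200 nM to 2500 nM.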

Compound 4, half-maximal inhibitory concentration: 3200 nM
The estimate for compound 4 lay 5.3-fold (0.73 log units) below the measured number; measured number outside the range, above it.
By their numbers in this assay, from the lowest: compound 3; then compounds 1, 4 and 2 (each within the scatter of the next).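

In this assay, a directly attached aromatic ring at this position does not by itself carry the low number of compound 3: replacing thiophen-2-yl with 4-chlorophenyl gives (a 7.8-fold higher number from compound 3 to compound 4 (0.89 log units; beyond the scatter)). Compound 4 instead falls level with the compounds bearing benzyl groups (a 1.3-fold lower number from compound 2 to compound 4 (0.12 log units; within the scatter); a 1.0-fold higher number from compound 1 to compound 4 (0.01 log units; within the scatter)), so the earlier gap tracks thiophen-2-yl itself in these four compounds, not direct attachment of any aromatic ring. Nothing available accounts for this difference.

This change swaps the ring and adds chlorine at once, so their separate contributions stay unresolved; phenyl, 4-chlorothiophen-2-yl or furan-2-yl would separate them. Also open, from the compounds shown here alone, is how an amine or a carboxylic acid on the attached ring would read at this position.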